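The compounds below may be only part of what the source reports. "The series", "measured", "known", "first", "only" and "open" are said of these compounds alone.

Series notes. Compound 1 `C#CCNC(=O)/C(C)=C(\C)c1ccc(OC)cc1` and compound 2 `C#CCNC(=O)/C(C)=C(\C)c1cc(OC)c(OC)c(OC)c1` share the propargylcarbamoyl side chain on different cores; how the two cores differ is not broken down here. In a toxicity assay on the whole organism (strain Icem-CET (SPF Caw)) for cytotoxicity, with Mus musculus as the target (on this read-out higher numbers stand for an effect only at larger amounts of compound and lower numbers for an effect already at smaller amounts), compound 1 gives 150 mg/kg, and compound 2 gives 150 mg/kg, level with compound 1 at the digits printed. Compound 3 `COc1ccc(/C(C)=C(\C)C(=O)NC2CC2)cc1` carries the change cyclopropyl in place of propargyl on an amide-type nitrogen relative to compound 1; in this assay compound 3 gives 250 mg/kg, a step of a 1.7-fold higher number from compound 1 to compound 3 (0.22 log units; within the scatter). Compound 4 `COc1cc(/C(C)=C(\C)C(=O)NC2CC2)cc(OC)c1OC` carries the same kind of change cyclopropyl in place of propargyl on an amide-type nitrogen relative to compound 2, on the core of compound 2; its place line reads the same as for compound 3. Compound 4 is not yet measured in this assay. Because the step of a 1.7-fold higher number from compound 1 to compound 3 (0.22 log units; within the scatter) was within the scatter, the step from compound 2 is expected to be similar, a 1.5-fold higher number from compound 2 to compound 4 (0.19 log units; within the scatter). Compound 4 is therefore estimated at 230 mg/kg in this assay, expected between 130 mg/kg and 400 mg/kg.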

Compound 4, dose for half-maximal effect: > 800 mg/kg
Compound 4 gave a limit, no number; the forecaster's own chance of this, stated with the estimate: 5%; at least 3.4-fold (0.54 log units) between middle value and limit.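

In this assay cyclopropyl in place of propargyl on an amide-type nitrogen does not keep the size of its step from one core to the other: the same change on two cores in this assay, a 1.7-fold higher number (0.22 log units; within the scatter) from compound 1 to compound 3 and an at least 5.3-fold higher number (0.72 log units; beyond the scatter) from compound 2 to compound 4, at least 3.2-fold (0.50 log units) apart, beyond the scatter of two such steps. On the core of compound 2 the change gives an at least 5.3-fold higher number from compound 2 to compound 4 (0.72 log units; beyond the scatter). As far as these compounds go, compound 4 gives > 800 mg/kg, a limit of the assay and not a number, so the full size of this step stays unknown, and two cores show neither why the steps differ nor how general the difference is.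

Open remain other groups on the same nitrogen, such as a longer chain or a chain carrying an amine. Also open, from the compounds shown here alone, is how this change behaves on any further core.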